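The source may hold more compounds than are shown below. What is called first, only, known or untested is meant among the compounds shown, and "the series" means these compounds.

The set rests on a shared core carrying an arylmethyl group on a nitrogen, examined in a functional assay on G-361 cells (Homo sapiens) for antiproliferative activity, with a stated time of 72 h; a lower number here means a stronger inhibitor, a higher number a weaker inhibitor. In this assay compound 1 `OC[C@H]1O[C@@H](n2cnc3c(NCc4cccc(C(F)(F)F)c4)ncnc32)[C@H](O)[C@@H]1O` gives > 166000 nM, which is a limit of the assay rather than a number. Compound 2 `OC[C@H]1O[C@@H](n2cnc3c(NCc4ccc(C(F)(F)F)cc4)ncnc32)[C@H](O)[C@@H]1O` likewise gives > 166000 nM, again only a limit. Compound 3 `OC[C@H]1O[C@@H](n2cnc3c(NCc4cccc(OC(F)(F)F)c4)ncnc32)[C@H](O)[C@@H]1O` also gives > 166000 nM, a limit as well. Compound 2 differs from compound 1 in that (4-(trifluoromethyl)phenyl in place of 3-(trifluoromethyl)phenyl on a saturated chain carbon bound to a nitrogen on an aromatic ring); the step that the two limits leave unreadable from compound 1 to compound 2 cannot be sized. Compound 3 differs from compound 1 in that (trifluoromethoxy in place of trifluoromethyl on an aromatic carbon), and a step that the two limits leave unreadable from compound 1 to compound 3 is equally unreadable because of the limit of > 166000 nM in this assay, at which 3 of the 3 values shown sit. Compound 4 `OC[C@H]1O[C@@H](n2cnc3c(NCc4ccc(OC(F)(F)F)cc4)ncnc32)[C@H](O)[C@@H]1O` is not yet measured; it differs from compound 2 in that (trifluoromethoxy in place of trifluoromethyl on an aromatic carbon). The surroundings are not identical: in compound 3 the entering group sits meta to a large group, in compound 4 para to a large group, so this is the same kind of change rather than the same change. With every measured value sitting at the limit, compound 4 is expected to show a step that the limit leaves unreadable from compound 2 to compound 4. Compound 4 is accordingly estimated at 200000 nM, most probably reported as a limit once more.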

Compound 4, half-maximal inhibitory concentration: > 166000 nM
Compound 4 gave a limit, no number; the forecaster's own chance of this, stated with the estimate: 90%; the middle value is on the limit's open side.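

In this assay compound 4 gives > 166000 nM, again a limit and not a number. No step can be read between compound 2 and compound 4, because both sit at the same limit: the limit of > 166000 nM in this assay, at which 4 of the 4 values shown sit.

The compounds shown leave open whether trifluoromethoxy and trifluoromethyl differ at all in this read-out, and how strongly any of these compounds inhibits.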